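The source may report more compounds than this note shows. Statements on the series, on what has been measured and on what is new or still open speak of the compounds shown alone.

Measured compounds:

compound 1 `Cc1cnc(NC(=O)COc2ccc(/C=C3\SC(=O)NC3=O)cc2)s1` — < 100000 nM
compound 2 `CCCCC1=NC2(CCCC2)C(=O)N1C(=O)COc1ccc(/C=C2/SC(=O)NC2=O)cc1` — < 100000 nM
compound 3 `O=C(COc1ccc(/C=C2\SC(=O)NC2=O)cc1)Nc1cccc(C(F)(F)F)c1` — < 100000 nM

All three were read in a functional assay on HepG2 cells (Homo sapiens) for cytotoxicity, read by sulforhodamine B assay, with a stated time of 48 h; a lower number here means a stronger inhibitor of growth, a higher number a weaker inhibitor of growth. The value given for compound 1 is not a number but a limit of the assay. The value for compound 2 is likewise only a limit. The value for compound 3 is a limit as well. In short, (the limit of < 100000 nM in this assay, at which 3 of the 3 values shown sit), so none of the three can be ranked against the others, and compound 1 stands among them at that limit with no number of its own.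

Compound 4 `O=C(COc1ccc(/C=C2\SC(=O)NC2=O)cc1)Nc1nc2ccccc2s1` has not been measured in this assay. It differs from compound 1 in a single place: 1,3-benzothiazol-2-yl in place of 5-methyl-1,3-thiazol-2-yl on an amide-type nitrogen. Among the compounds with values here, no step between measured compounds that differ in one place is available, and none of the three measured values offers a number against which a step could be set. The change is expected to bring a shift that is small and not clearly beyond the scatter, estimated as a step that the limit leaves unreadable from compound 1 to compound 4. For compound 4 in this assay the estimated value is 40000 nM, with an expected range from 8000 nM to 100000 nM, and a report of only a limit again is considered likely.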

Compound 4, concentration for 50% growth inhibition: < 100000 nM
Compound 4 was reported as a limit; the forecaster's own chance of this, stated with the estimate: 65%; the middle value lies beyond the limit too.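

Compound 1 and compound 4 are both reported only as limits of the assay, so no step can be read between them, and the change from 5-methyl-1,3-thiazol-2-yl to 1,3-benzothiazol-2-yl stays without a size: the limit of < 100000 nM in this assay, at which 4 of the 4 values shown sit. The compounds shown leave open how the four rank against one another in this assay and whether this change shifts growth inhibition at all.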